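A Fluoro Group on the Phenyl Ring of Compound 2

The source may report more compounds than this note shows. Statements on the series, on what has been measured and on what is new or still open speak of the compounds shown alone.

Measured in a toxicity assay on HepG2 2.2.15 cells (Homo sapiens) for cytotoxicity, read by CellTiter-Glo; a higher number here means that more compound is tolerated, a lower number that less compound is tolerated:
- Compound 1 `O=C(Nc1cc(F)c(F)c(F)c1)N1Cc2c(-c3ccc(F)cc3F)cnn2CC1C1CC1`: 32100 nM
- Compound 2 `O=C1OC(c2ccccc2)CN1c1cnn2c1CN(C(=O)Nc1cc(F)c(F)c(F)c1)C(C1CC1)C2`: 7410 nM

Compound 2 holds the lower of these two numbers. Compound 3 `O=C1OC(c2ccc(F)cc2)CN1c1cnn2c1CN(C(=O)Nc1cc(F)c(F)c(F)c1)C(C1CC1)C2` carries fluoro in place of hydrogen on an aromatic carbon of compound 2: fluoro in place of hydrogen on an aromatic carbon. Going by the values given here, the only measured step, a 4.3-fold lower number from compound 1 to compound 2 (0.64 log units; beyond the scatter), exchanged a whole substituent, so it offers little guide to so small a change. No step beyond the scatter is therefore expected in this assay. The expected step is a 1.1-fold lower number from compound 2 to compound 3 (0.02 log units; within the scatter). Compound 3 is estimated at 7000 nM, with an expected range of 3500 nM to 14000 nM.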

Compound 3, half-maximal cytotoxic concentration: 3560 nM
Compound 3: the middle estimate sits 2.0-fold (0.29 log units) above what was measured; measured number inside the range.
By their numbers in this assay, from the lowest: compound 3; then compound 2; then compound 1.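

In this assay the change from phenyl to 4-fluorophenyl gives a 2.1-fold lower number from compound 2 to compound 3 (0.32 log units; beyond the scatter) and so lowers the tolerated concentration. A single fluoro on this aromatic carbon, para to a large group, is thus enough to move the number beyond the scatter, which the earlier exchange of a whole substituent could not show. No measurement here explains the step. The compounds shown leave open whether chloro, methoxy or an amine at this carbon would lower the number further or raise it again.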